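Adding a Methyl and Shifting the Chlorine: Stability Outlook

A few compounds are considered here, and "the series" means these few. Any claim that something is new, unique, unknown or untested is made for them only; others in the source may bear on it.

Compound 1 `Nc1nc(NCCNc2ncc(-c3ncc[nH]3)c(-c3ccccc3Cl)n2)ccc1[N+](=O)[O-]` was tested in an ADME assay on microsomes from liver (Rattus norvegicus) for metabolic stability; on this read-out higher numbers stand for a longer-lived compound and lower numbers for a shorter-lived compound. In this assay compound 1 gives > 0.5 h, which is a limit of the assay rather than a number. Compound 2 `Nc1nc(NCCNc2ncc(-c3ncc[nH]3)c(-c3ccccc3Br)n2)ccc1[N+](=O)[O-]` differs from compound 1 by bromo in place of chloro on an aromatic carbon. In this assay compound 2 gives > 0.5 h, again only a limit. The step from compound 1 to compound 2 in this assay is therefore a step that the two limits leave unreadable from compound 1 to compound 2, because of the limit of > 0.5 h in this assay, at which 2 of the 2 values shown sit. Compound 1 thus stands at a limit only, with no number of its own to place it.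

Compound 3 `Cc1cc(Cl)ccc1-c1nc(NCCNc2ccc([N+](=O)[O-])c(N)n2)ncc1-c1ncc[nH]1` changes compound 1 by 4-chloro-2-methylphenyl in place of 2-chlorophenyl on an aromatic carbon. Among the measured compounds shown here, the single measured step, the exchange of one halogen for another on the same ring, bears on this change, but its size is hidden by the two limits, so it offers no direction. For that reason no shift beyond the scatter is expected in this assay, and the estimated step is a step that the limit leaves unreadable from compound 1 to compound 3. Compound 3 is expected to give about 1 h in this assay, somewhere from 0.5 h to 3 h, and the read-out may well return as a limit once more.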

Compound 3, half-life: > 0.5 h
Compound 3: only a limit was reported; the forecaster's own chance of this, stated with the estimate: 60%; the middle value does not contradict the limit.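

In this assay compound 3 gives > 0.5 h as a limit of the assay and not a number. Among the compounds shown here, no step among compound 1, compound 2 and compound 3 can be read, because of what all three share: the limit of > 0.5 h in this assay, at which 3 of the 3 values shown sit. The compounds shown leave open how long each one actually survives in this assay and whether their half-lives differ at all.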